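This account rests on a few compounds, and the source may have more. Where it says the series, first, only, none or still open, it means among the compounds named here.

Compound 1, `Cc1cc(C(=O)N[C@H]2CCN(Cc3ccc(OCCCN(C)C)cc3)C2)ccc1Br`, in an assay on HEK293 cells for binding affinity to Urotensin-2 receptor (Homo sapiens), read by radioligand binding (on this read-out lower numbers stand for stronger inhibition and higher numbers for weaker inhibition), gives 631 nM. Compound 3, `CC(C)C[C@H](NC(=O)c1ccc(Cl)c(Cl)c1)C(=O)N[C@H]1CCN(Cc2ccc(OCCCN(C)C)cc2)C1`, in this assay gives 126 nM. Compound 2, `CC(=O)N[C@H]1CCN(Cc2ccc(OCCCN(C)C)cc2)C1`, in this assay reaches only a limit of the assay, < 10000 nM.

Among the two numbers shown, compound 3 holds the lower one; its gap to compound 1 lies beyond the scatter. Among the measured compounds shown here, the single step between compounds that differ in one place, a step that the limit leaves unreadable from compound 1 to compound 2, cannot be read in size because of the limit of < 10000 nM in this assay, at which 1 of the 3 values shown sits.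

Compound 4, `CC(C)C[C@H](NC(=O)c1ccco1)C(=O)N[C@H]1CCN(Cc2ccc(OCCCN(C)C)cc2)C1`, differs from compound 3 in one place: furan-2-yl in place of 3,4-dichlorophenyl on a carbonyl carbon. For the measured compounds named here, no measured step exchanges one aromatic group for another on that carbonyl carbon, so no step bears directly on this change. The only hint is that the shared core with a small acetyl group, compound 2, stays at a limit, while both aryl amides give numbers; a smaller aromatic ring is therefore expected to weaken binding somewhat, a 3.2-fold higher number from compound 3 to compound 4 (0.50 log units; beyond the scatter). Compound 4 is estimated at 400 nM, expected between 120 nM and 1500 nM.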

Compound 4, inhibition constant: 631 nM
Beside the measured number, compound 4's estimate is 1.6-fold (0.20 log units) below it, and the stated range covers the measured number.
By their numbers in this assay, from the lowest: compound 3; then compounds 1 and 4 (each within the scatter of the next).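

Among the compounds shown here, at the carbonyl carbon whose other neighbour is an amide-type nitrogen, the first exchange of one aromatic group for another in this assay gives a 5.0-fold higher number from compound 3 to compound 4 (0.70 log units; beyond the scatter). The 3,4-dichlorophenyl group can therefore give way to furan-2-yl at a measurable cost, while compound 4 still returns a number and not a limit. What lies behind this step is not shown by any measurement here.

This single exchange changes the ring size, removes both chlorine atoms and brings in a ring oxygen, so the compounds shown leave open which of these changes accounts for the step. Going by these compounds, a plain phenyl, a 4-chlorophenyl or a thiophen-2-yl on this carbonyl carbon could help to separate them, and how a pyridin-3-yl would fare there also remains open.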